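A Chloro Step Repeated on a Second Core

A few compounds are considered here, and "the series" means these few. Any claim that something is new, unique, unknown or untested is made for them only; others in the source may bear on it.

compound 1 `COc1cc(F)c(NC(=O)c2ccncc2)cc1Nc1nccc(-c2cn(C)c3ccccc23)n1`: 4200 nM
compound 2 `COc1cc(F)c(NC(=O)c2ccnc(Cl)c2)cc1Nc1nccc(-c2cn(C)c3ccccc23)n1`: 6890 nM
compound 3 `COc1cc(N(C)C)c(NC(=O)c2ccncc2)cc1Nc1nccc(-c2cn(C)c3ccccc23)n1`: 9000 nM

All three compounds were measured in a functional assay on A549 cells (Homo sapiens) for antiproliferative activity, read by MTT assay, with a stated time of 72 h; on this read-out higher numbers stand for weaker inhibition and lower numbers for stronger inhibition. Compound 2 differs from compound 1 by chloro in place of hydrogen on an aromatic carbon, and that change gave a 1.6-fold higher number from compound 1 to compound 2 (0.21 log units; within the scatter). Compound 3 differs from compound 1 by dimethylamino in place of fluoro on an aromatic carbon, a change that gave a 2.1-fold higher number from compound 1 to compound 3 (0.33 log units; beyond the scatter). Compound 4 `COc1cc(N(C)C)c(NC(=O)c2ccnc(Cl)c2)cc1Nc1nccc(-c2cn(C)c3ccccc23)n1` has not yet been measured. It differs from compound 3 by chloro in place of hydrogen on an aromatic carbon, and the place where the chloro enters is described in exactly the same words as for the change from compound 1 to compound 2, so this is the same change, now made on the core that carries dimethylamino in place of fluoro. The step is expected to be a 1.6-fold higher number from compound 3 to compound 4 (0.19 log units; within the scatter), because the earlier one was a 1.6-fold higher number from compound 1 to compound 2 (0.21 log units; within the scatter) and nothing among these three compounds shows the change behaving differently on the second core. Compound 4 is therefore expected to give about 14000 nM in this assay, with a likely range from 7000 nM to 28000 nM.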

Compound 4, half-maximal inhibitory concentration: 3430 nM
Compound 4: the middle estimate sits 4.1-fold (0.61 log units) above what was measured, outside the stated range (below it).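

In this assay, adding the chloro to the core that carries dimethylamino gave a 2.6-fold lower number from compound 3 to compound 4 (0.42 log units; beyond the scatter), so the step seen on the core of compound 1 did not carry over: the same change on two cores in this assay, a 1.6-fold higher number (0.21 log units; within the scatter) from compound 1 to compound 2 and a 2.6-fold lower number (0.42 log units; beyond the scatter) from compound 3 to compound 4, 4.3-fold (0.63 log units) apart, beyond the scatter of two such steps. The same result appears when the other change is followed, with dimethylamino in place of fluoro giving a 2.0-fold lower number from compound 2 to compound 4 (0.30 log units; within the scatter) once the chloro is present, which does not match the step without it: the same change on two cores in this assay, a 2.1-fold higher number (0.33 log units; beyond the scatter) from compound 1 to compound 3 and a 2.0-fold lower number (0.30 log units; within the scatter) from compound 2 to compound 4, 4.3-fold (0.63 log units) apart, beyond the scatter of two such steps. This shows that, for these four compounds, the size and direction of each step depend on what sits at the other place, so the two steps cannot simply be added together, but it does not show why this happens or whether it holds on any other core.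

Going by these compounds, it remains open whether another group in place of the chloro, such as a methyl group or a nitrile, would show the same dependence on the core. On these data alone, it is also open whether a different amine in place of dimethylamino, such as morpholine, would behave as dimethylamino does here.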